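Replacing the sulfonyl group of compound 3

This account rests on a few compounds, and the source may have more. Where it says the series, first, only, none or still open, it means among the compounds named here.

Values measured in a functional assay on MGC-803 cells (Homo sapiens) for cytotoxicity, read by MTT assay, with a stated time of 48 h (on this read-out lower numbers stand for stronger inhibition and higher numbers for weaker inhibition), are:
compound 1 `CC1=NN(C(=O)CCl)C(c2cc(Br)ccc2O)C1` gives 13500 nM
compound 2 `O=c1oc2ccccc2cc1C1=NN(S(=O)(=O)c2ccc([N+](=O)[O-])cc2)C(c2ccccc2)C1` gives 41200 nM
compound 3 `Cc1ccc(S(=O)(=O)N2N=C(c3cc4ccccc4oc3=O)CC2c2ccccc2)cc1` gives 50200 nM

Compound 3 sits level with compound 2 within the scatter, and both show higher numbers, meaning weaker inhibition, than compound 1. For the measured compounds named here, the change from compound 3 to compound 4 `O=C(CN1CCCC1)N1N=C(c2cc3ccccc3oc2=O)CC1c1ccccc1` is ((pyrrolidin-1-yl)methyl)carbonyl in place of (4-methylphenyl)sulfonyl on an amine nitrogen in a ring and no measured step makes this swap. Going by the values given here, the only measured step is a 1.2-fold higher number from compound 2 to compound 3 (0.09 log units; within the scatter) and it is methyl in place of nitro on an aromatic carbon, which keeps the sulfonyl and so says little here. Compound 1 does carry a carbonyl on an amine nitrogen in a ring and gives 13500 nM but its core differs. A modest move to a lower number is therefore expected, with a 2.3-fold lower number from compound 3 to compound 4 (0.36 log units; beyond the scatter) as the estimated step. Compound 4 is estimated at 22000 nM within an expected range of 7000 nM to 60000 nM on this thin evidence.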

Compound 4, half-maximal inhibitory concentration: "not active" (no number reported)
No number was reported for compound 4; there is nothing to compare the estimate with.
By their numbers in this assay, from the lowest: compound 1; then compounds 2 and 3 (each within the scatter of the next).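

For the compounds shown here, compound 4 is reported as "not active" with no number, so no step from compound 3 can be read. No evidence here explains this result. From the compounds shown here alone, how far ((pyrrolidin-1-yl)methyl)carbonyl moves the number in this assay stays open.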